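Shortening the amine side and lengthening the linker

The source may report more compounds than this note shows. Statements on the series, on what has been measured and on what is new or still open speak of the compounds shown alone.

Of the compounds shown here, two that share a core have been measured. Compound 1 `CCN(CC)CCCOc1ccc(C(=O)/C=C/c2ccc(N(C)C)cc2)c(O)c1` gives 4100 nM in an assay on isolated protein for inhibition of Amine oxidase [flavin-containing] B (Homo sapiens); a lower number here means a stronger inhibitor, a higher number a weaker inhibitor. Compound 2 `CCN(CCCOc1ccc(C(=O)/C=C/c2ccc(N(C)C)cc2)c(O)c1)Cc1ccccc1OC` gives 10800 nM in this assay. Within the data shown here, compound 2 thus stands at the weaker end of the two numbers, and the single step that separates them, a 2.6-fold higher number from compound 1 to compound 2 (0.42 log units; beyond the scatter), shows that enlarging the substituent on the amine nitrogen from methyl to 2-methoxyphenyl cost a modest amount of inhibition.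

Compound 3 `CCN(CCCCOc1ccc(C(=O)/C=C/c2ccc(N(C)C)cc2)c(O)c1)Cc1ccccc1` is not yet measured. It differs from compound 2 in one place: (benzyl(ethyl)amino)methyl in place of ethyl(2-methoxybenzyl)amino on a saturated chain carbon, three bonds along the chain from an oxygen on an aromatic ring. In plain terms, the methoxy group on the benzyl ring is gone and the chain between the amine nitrogen and the aromatic oxygen is one carbon longer.

Among the measured compounds shown here, no measured step covers this exact change. For the measured compounds named here, the only step on record concerns the size of the group on the amine nitrogen, and it was modest. With so little to go on, compound 3 is expected to sit close to compound 2, with a step of a 1.2-fold lower number from compound 2 to compound 3 (0.08 log units; within the scatter) that may well fall within the scatter. Compound 3 is therefore estimated at 9000 nM, within a range from 4000 nM to 20000 nM.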

Compound 3, half-maximal inhibitory concentration: 8900 nM
Beside the measured number, compound 3's estimate is 1.0-fold (0.00 log units) above it; measured number inside the range.
By their numbers in this assay, from the lowest: compound 1; then compounds 3 and 2 (each within the scatter of the next).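

In this assay the step of a 1.2-fold lower number from compound 2 to compound 3 (0.08 log units; within the scatter) leaves the two numbers indistinguishable, even though the methoxy group left the benzyl ring and the chain gained one carbon in the same move. The step of a 2.2-fold higher number from compound 1 to compound 3 (0.34 log units; beyond the scatter) shows that the (benzyl(ethyl)amino)methyl group also gives weaker inhibition than the diethylamino compound, so the loss seen with the 2-methoxybenzyl group does not depend on the methoxy group being present. Nothing available explains why these numbers fall where they do.

Going by these compounds, since two things changed at once in the step to the newest compound, the separate contribution of the methoxy group and of the extra chain carbon remains unknown, and the two could even cancel each other. Also open, on these data alone, is how inhibition would respond to a still longer chain, or to a piperidine ring or a morpholine ring in place of the open-chain amine.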